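Swapping a Phenol Hydroxy for a Methyl Ester

This account rests on a few compounds, and the source may have more. Where it says the series, first, only, none or still open, it means among the compounds named here.

Compound 2 `O=C(CCCCCCc1ccc(O)cc1)N1CCCC1` carries a hydroxy group on its aromatic ring. In an assay on HEK293 cells for inhibition of N-acylethanolamine-hydrolyzing acid amidase (Rattus norvegicus), read by LC-MS, with a stated time of 30 min (on this read-out lower numbers stand for stronger inhibition and higher numbers for weaker inhibition), compound 2 gives 5600 nM. Among the measured compounds shown here, only one other compound has been measured, compound 1 `Cc1ccc(CCCCCCC(=O)N2CCCC2)cc1`, which differs by having a methyl group at that same aromatic carbon; in this assay compound 1 gives 9600 nM. The two numbers sit close together: a 1.7-fold lower number from compound 1 to compound 2 (0.23 log units; within the scatter). Exchanging methyl for hydroxy at this aromatic carbon therefore produced nothing that can be told apart from the ordinary spread of repeated measurements.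

Compound 3 `COC(=O)c1ccc(CCCCCCC(=O)N2CCCC2)cc1` is the next step. Its change from compound 2 is this: methoxycarbonyl in place of hydroxy on an aromatic carbon. For the measured compounds named here, no measured step covers this exact exchange. Going by the values given here, the single step that does exist, methyl to hydroxy, stayed within the scatter, so the one piece of evidence about varying the group at this aromatic carbon points to a small effect. Compound 3 is accordingly expected to move little, with a 1.1-fold higher number from compound 2 to compound 3 (0.03 log units; within the scatter) in this assay. The estimate for compound 3 is 6000 nM, with a range from 2000 nM to 20000 nM.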

Compound 3, half-maximal inhibitory concentration: > 100000 nM
Compound 3: no number, only a limit; the forecaster's own chance of this, stated with the estimate: 10%; at least 16-fold (1.22 log units) between middle value and limit.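

Compound 3 has no number, only a limit of the read-out in this assay: the limit of > 100000 nM in this assay, at which 1 of the 3 values shown sits.

This aromatic carbon, para to a large group, therefore does respond to what sits on it: methyl and hydroxy stayed within the scatter of each other, whereas methoxycarbonyl gives an at least 17-fold higher number from compound 2 to compound 3 (1.25 log units; beyond the scatter) and an at least 10-fold higher number from compound 1 to compound 3 (1.01 log units; beyond the scatter) in the other comparison. Both steps are beyond the scatter, and since compound 3 rests on a limit, each gives only the smallest possible size of the change, with the true size unknown. Compared with the hydroxy of compound 2, the entering methoxycarbonyl has 4 heavy atoms rather than 1, a double bond outside aromatic rings and 0 hydrogen-bond donors, so the exchange alters several things at once.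

The compounds shown cannot say which of these differences matters, and a single ester gives no way to separate them. Going by these compounds, a carboxylic acid, a primary amide or an amine on this same aromatic carbon would help to do so, as would an ethyl ester, and the effect of a longer chain on this series also remains open.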